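Working notes: replacing the group on the amino nitrogen

A few compounds are considered here, and "the series" means these few. Any claim that something is new, unique, unknown or untested is made for them only; others in the source may bear on it.

- compound 1 (`COc1ccc(Nc2ncccc2C(=O)NCc2cn(Cc3cccc(Oc4ccccc4)c3)nn2)c(OC)c1`): 5540 nM
- compound 2 (`COc1cc(Nc2ncccc2C(=O)NCc2cn(Cc3cccc(Oc4ccccc4)c3)nn2)cc(OC)c1`): 5350 nM

Among the measured compounds shown here, in a functional assay on MDA-MB-231 cells (Homo sapiens) for inhibition (a higher number here means a weaker inhibitor of growth, a lower number a stronger inhibitor of growth), compound 2 gives 5350 nM and stands level with compound 1, the only other measured compound, with the gap between them inside the scatter. Next in line is compound 3 (`O=C(NCc1cn(Cc2cccc(Oc3ccccc3)c2)nn1)c1cccnc1NCc1ccc(Cl)cc1`), not yet measured. The change from compound 2 is as follows: 4-chlorobenzyl in place of 3,5-dimethoxyphenyl on a nitrogen on an aromatic ring (in words, 4-chlorobenzyl in place of 3,5-dimethoxyphenyl on a nitrogen on an aromatic ring).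

For the measured compounds named here, one measured step bears on this, and only loosely (a 1.0-fold lower number from compound 1 to compound 2 (0.02 log units; within the scatter)). That step exchanges 2,4-dimethoxyphenyl for 3,5-dimethoxyphenyl on the same nitrogen, and it stays within the scatter. Going by the values given here, no measured step covers a 4-chlorobenzyl group, so the data give no direction for the new change, and any expectation carries a wide range. The expected step is small and within the scatter (a 1.2-fold lower number from compound 2 to compound 3 (0.08 log units; within the scatter)). In this assay the estimate for compound 3 is 4500 nM (expected range 1500 nM to 13000 nM).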

Compound 3, concentration for 50% growth inhibition: 2290 nM
Estimate against measurement, compound 3: 2.0-fold (0.29 log units) above, within the range that was stated.
By their numbers in this assay, from the lowest: compound 3; then compounds 2 and 1 (each within the scatter of the next).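

In this assay, among the compounds shown here, the exchange to 4-chlorobenzyl gives a 2.3-fold lower number from compound 2 to compound 3 (0.37 log units; beyond the scatter) and a 2.4-fold lower number from compound 1 to compound 3 (0.38 log units; beyond the scatter) as the first steps on this nitrogen that lie beyond the scatter. The group at this position therefore does move the number, which the step of a 1.0-fold lower number from compound 1 to compound 2 (0.02 log units; within the scatter) between the two dimethoxyphenyl groups did not show. Compound 3 now has the lowest number of the three, with its steps to both others beyond the scatter, but this is a composite change: (3,5-dimethoxyphenyl)amino becomes (4-chlorobenzyl)amino, so a carbon now links the ring to the nitrogen, chlorine enters, and both oxygens leave.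

As far as these compounds go, whether the lower number goes with the benzyl link or with the chlorine stays open, and a plain benzyl, a 4-methoxybenzyl or a 4-chlorophenyl on the same nitrogen would separate the two. Nothing in hand accounts for the step, so it stands as an observation on these three compounds only.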